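A few compounds are considered here, and "the series" means these few. Any claim that something is new, unique, unknown or untested is made for them only; others in the source may bear on it.

Compound 1 (`CN1C/C(=C\c2cccnc2)C(=O)/C(=C/c2ccccc2C(F)(F)F)C1`) gives 3900 nM in a functional assay on SMMC-7721 cells (Homo sapiens) for cytotoxicity, read by MTT assay, with a stated time of 24 h; a lower number here means a stronger inhibitor, a higher number a weaker inhibitor. Compound 2 (`O=C1/C(=C/c2cccnc2)CN(S(=O)(=O)c2ccc([N+](=O)[O-])cc2)C/C1=C\c1ccccc1C(F)(F)F`) gives 15900 nM, and (4-nitrophenyl)sulfonyl in place of methyl on an amine nitrogen in a ring accounts for a 4.1-fold higher number from compound 1 to compound 2 (0.61 log units; beyond the scatter). Compound 3 (`O=C1/C(=C/c2cccnc2)CN(S(=O)(=O)c2ccc(C(F)(F)F)cc2)C/C1=C\c1ccccc1C(F)(F)F`) gives 1730 nM, the lowest of the three values in this assay. The next change starts from compound 3 and leads to compound 4 (`N#Cc1ccc(S(=O)(=O)N2C/C(=C\c3cccnc3)C(=O)/C(=C/c3ccccc3C(F)(F)F)C2)cc1`): cyano in place of trifluoromethyl on an aromatic carbon.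

For the measured compounds named here, the closest evidence is the only measured change at this aromatic carbon, trifluoromethyl in place of nitro, which gave a 9.2-fold lower number from compound 2 to compound 3 (0.96 log units; beyond the scatter). The step from methyl to the sulfonyl group bears on it only loosely. Going by the values given here, no cyano compound has been measured, so the direction is uncertain. Since compound 3 holds the lowest value at 1730 nM, a modest move to a higher number is expected, smaller in size than the nitro step. The expected change is an estimated 2.6-fold higher number from compound 3 to compound 4 (0.42 log units; beyond the scatter). Compound 4 is estimated at 4500 nM, with an expected range of 1500 nM to 13000 nM.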

Compound 4, half-maximal inhibitory concentration: 9650 nM
Compound 4: middle estimate off by 2.1-fold (0.33 log units), on the low side; low and high end bracket the measured number.
By their numbers in this assay, from the lowest: compound 3; then compound 1; then compounds 4 and 2 (each within the scatter of the next).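

At the aromatic carbon para to a large group, this assay now separates trifluoromethyl from cyano as well as from nitro (a 5.6-fold higher number from compound 3 to compound 4 (0.75 log units; beyond the scatter)). Cyano and nitro cannot be told apart here (a 1.6-fold lower number from compound 2 to compound 4 (0.22 log units; within the scatter)), so among the three groups only trifluoromethyl stands apart, on the side of the lower number. Replacing methyl on the ring nitrogen with (4-cyanophenyl)sulfonyl gives a higher number (a 2.5-fold higher number from compound 1 to compound 4 (0.39 log units; beyond the scatter)), as the 4-nitrophenyl version does, so a sulfonyl group there does not alone set the direction: compound 1 gives 3900 nM, whereas compound 3 gives 1730 nM.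

No measurement at hand accounts for the position of trifluoromethyl apart from the other two groups. Going by these compounds, how an amine, a carboxylic acid or a methoxy group at this carbon would compare remains open.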